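This account rests on a few compounds, and the source may have more. Where it says the series, first, only, none or still open, it means among the compounds named here.

Measured in a functional assay on Ehrlich cells (Mus musculus) for cytotoxicity, read by trypan blue exclusion, with a stated time of 2 h, tested at 25 ug/mL; on this read-out lower numbers stand for a weaker effect and higher numbers for a stronger effect at the one concentration tested:
compound 1 `C=CCNC(=S)NC1=C(C#N)C(c2ccc(Cl)cc2Cl)C2=C(CCCC2=O)N1c1ccc(S(N)(=O)=O)cc1` — 30%
compound 2 `N#CC1=C(NC(=S)Nc2ccccc2)N(c2ccc(S(N)(=O)=O)cc2)C2=C(C(=O)CCC2)C1c1ccc(Cl)cc1Cl` — 50%
compound 3 `N#CC1=C(NC(=S)Nc2ccc(Cl)cc2)N(c2ccc(S(N)(=O)=O)cc2)C2=C(C(=O)CCC2)C1c1ccc(Cl)cc1Cl` — 60%

Compound 2 stands second highest of the three numbers; its nearest neighbour is compound 3, a number 10 percentage points higher from compound 2 to compound 3 (within the scatter), and the furthest is compound 1, a number 20 percentage points higher from compound 1 to compound 2 (beyond the scatter). The unmeasured compound 4 `N#CC1=C(NC(=O)CCC(=O)O)N(c2ccc(S(N)(=O)=O)cc2)C2=C(C(=O)CCC2)C1c1ccc(Cl)cc1Cl` differs from compound 2 in one place: a group of 7 heavy atoms (4 carbon, 3 oxygen; no ring) in place of a group of 9 heavy atoms (7 carbon, 1 nitrogen, 1 sulfur; one six-membered aromatic ring of carbon only), on an amine nitrogen. For the measured compounds named here, no measured step exchanges the aromatic ring on this nitrogen for a group without a ring. The closest comparisons are the replacements of allyl, which has no ring, by a six-membered aromatic ring: a number 20 percentage points higher from compound 1 to compound 2 (beyond the scatter) and a number 30 percentage points higher from compound 1 to compound 3 (beyond the scatter). Read backwards, they say that a nitrogen substituent without a ring went with a lower number. Compound 4 likewise carries no ring at this position, so a decrease in this assay of roughly that size is expected. For compound 4 the expected step is a number 20 percentage points lower from compound 2 to compound 4 (beyond the scatter). For compound 4 the estimate is 30%, with a range from 15% to 50%. Going by the values given here, the range is kept wide; only two steps bear on the change and neither involves the entering group.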

Compound 4, a percentage reported as activity, at one concentration (the size of the read-out at that concentration, not a potency): 35%
Compound 4: middle estimate off by 5 percentage points, on the low side; the measured number falls inside the stated range.
By their numbers in this assay, from the lowest: compounds 1 and 4 (each within the scatter of the next); then compounds 2 and 3 (each within the scatter of the next).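

In this assay, the (2-carboxyethyl)carbonyl group on this amine nitrogen, which has no ring, now stands directly against the groups with a six-membered aromatic ring: a number 15 percentage points lower from compound 2 to compound 4 (beyond the scatter) and a number 25 percentage points lower from compound 3 to compound 4 (beyond the scatter). Against the other group without a ring, the reading is a number 5 percentage points higher from compound 1 to compound 4 (within the scatter), so two ring-free groups of different make-up are not separated here, and across the four compounds both ring-bearing groups give the higher numbers, with no compound going against this. No measurement at hand bears on what lies behind these differences.

As far as these compounds go, whether the aromatic ring itself matters, or something else in the exchanged groups, remains open. A cyclohexyl group on the same nitrogen, or the methyl ester of the carboxylic acid, would speak to this.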